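Swapping an Ester for a Nitrile on a Shared Core

This account rests on a few compounds, and the source may have more. Where it says the series, first, only, none or still open, it means among the compounds named here.

Three measured compounds share one core and differ only in the group attached to a double-bonded ring carbon. Compound 1 `COc1ccc2c(c1)OC(c1cc(OC)c(OC)c(OC)c1)C(C(=O)NC(C)(C)C)=C2` bears a tert-butyl amide there, and in a functional assay for inhibition of nuclear factor NF-kappa-B complex (Homo sapiens) (a lower number here means a stronger inhibitor, a higher number a weaker inhibitor), compound 1 gives 28400 nM. Compound 2 `COc1ccc2c(c1)OC(c1cc(OC)c(OC)c(OC)c1)C(C=O)=C2` bears an aldehyde, and in this assay compound 2 gives 13500 nM. Compound 3 `CCOC(=O)C1=Cc2ccc(OC)cc2OC1c1cc(OC)c(OC)c(OC)c1` bears an ethyl ester, and in this assay compound 3 gives 25000 nM. Compound 3 is therefore near compound 1 (a 1.1-fold lower number from compound 1 to compound 3 (0.06 log units; within the scatter)) and near compound 2 (a 1.9-fold higher number from compound 2 to compound 3 (0.27 log units; within the scatter)); neither gap passes the scatter.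

Compound 4 `COc1ccc2c(c1)OC(c1cc(OC)c(OC)c(OC)c1)C(C#N)=C2` has not yet been measured. It differs from compound 3 by cyano in place of ethoxycarbonyl on a double-bonded ring carbon. Going by the values given here, every change so far at this position has shifted the number only a little: the one step that did pass the scatter, a 2.1-fold lower number from compound 1 to compound 2 (0.32 log units; beyond the scatter), was modest, and the other two stayed inside it. With three such small moves behind it, the switch to a cyano group is expected to give a small step, if any, and its direction cannot be fixed from these data; the estimate is a 1.4-fold lower number from compound 3 to compound 4 (0.14 log units; within the scatter). For compound 4 in this assay the expected value is 18000 nM, with a range from 6000 nM to 50000 nM.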

Compound 4, half-maximal inhibitory concentration: 3400 nM
Compound 4: the middle estimate sits 5.3-fold (0.72 log units) above what was measured; the whole stated range lies above it.
By their numbers in this assay, from the lowest: compound 4; then compounds 2, 3 and 1 (each within the scatter of the next, the first and the last beyond it).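

Compound 4 shows that this position is more sensitive than the amide, aldehyde and ester suggested: in this assay the cyano group stands apart from all three, with a 7.4-fold lower number from compound 3 to compound 4 (0.87 log units; beyond the scatter), a 4.0-fold lower number from compound 2 to compound 4 (0.60 log units; beyond the scatter) and an 8.4-fold lower number from compound 1 to compound 4 (0.92 log units; beyond the scatter). All three steps lie beyond the scatter, which makes compound 4 the strongest inhibitor of the four, and the result also shows that a group with no carbonyl and fewer heavy atoms than ethoxycarbonyl can be tolerated here and can give a much lower number. Nothing measured here explains the gain, so the loss of the carbonyl, the smaller group and the triple bond cannot be told apart as its source.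

A methyl group, a chlorine atom, an ethynyl group or a carboxylic acid on the same ring carbon would help show whether the lower number belongs to the nitrile itself or is shared by other groups without a carbonyl or with few heavy atoms. On these data alone, it also remains open whether the nitrile keeps this advantage when the methoxy groups elsewhere on the shared core are replaced by hydrogen or by a longer chain such as propoxy.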